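This account rests on a few compounds, and the source may have more. Where it says the series, first, only, none or still open, it means among the compounds named here.

The measured compounds:

Compound 1, `N#Cc1ccc(NC(=O)C(=O)N2CCC(c3ccnc4ccc(F)cc34)CC2)cc1`, gives 5500 nM in an assay on HEK cells for inhibition of Tryptophan 2,3-dioxygenase (Homo sapiens); on this read-out higher numbers stand for weaker inhibition and lower numbers for stronger inhibition.
Compound 2, `O=C(Nc1ccc(C(F)(F)F)cc1)C(=O)N1CCC(c2ccnc3ccc(F)cc23)CC1`, gives 9500 nM in this assay.
Compound 3, `O=C(Nc1ccc(C(F)F)cc1)C(=O)N1CCC(c2ccnc3ccc(F)cc23)CC1`, gives 5800 nM in this assay.

The three share one core and differ only in the group carried by the aromatic ring at the amide end. Compound 3 stands close to both of the others: a 1.1-fold higher number from compound 1 to compound 3 (0.02 log units; within the scatter) and a 1.6-fold lower number from compound 2 to compound 3 (0.21 log units; within the scatter), each within the scatter, as is a 1.7-fold higher number from compound 1 to compound 2 (0.24 log units; within the scatter). Exchanging nitrile, trifluoromethyl and difluoromethyl on that ring therefore produces no shift that can be told apart from repeat measurements.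

Compound 4, `O=C(Nc1ccc(Cl)cn1)C(=O)N1CCC(c2ccnc3ccc(F)cc23)CC1`, has not been measured. It differs from compound 3 in one place: 5-chloropyridin-2-yl in place of 4-(difluoromethyl)phenyl on an amide-type nitrogen. This is a change of a different kind from the measured ones, since the whole ring is exchanged rather than the group attached to it. For the measured compounds named here, no measured step covers such an exchange; the measured steps only show that this part of the molecule has so far accepted variation without a change beyond the scatter. On that basis the expected step is a 1.0-fold higher number from compound 3 to compound 4 (0.01 log units; within the scatter), with wide uncertainty. Compound 4 is expected to give about 6000 nM in this assay, within a range from 1500 nM to 25000 nM.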

Compound 4, half-maximal inhibitory concentration: 5900 nM
Compound 4: the middle estimate sits 1.0-fold (0.01 log units) above what was measured, within the range that was stated.
By their numbers in this assay, from the lowest: compounds 1, 3, 4 and 2 (each within the scatter of the next).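

Compounds 1 to 3 varied only the group carried by an aromatic ring, whereas compound 4 exchanges the ring itself, and in this assay this gives a 1.0-fold higher number from compound 3 to compound 4 (0.01 log units; within the scatter), a 1.6-fold lower number from compound 2 to compound 4 (0.21 log units; within the scatter) and a 1.1-fold higher number from compound 1 to compound 4 (0.03 log units; within the scatter). The place on the amide-type nitrogen therefore accepts not only a ring of carbon only but also 5-chloropyridin-2-yl, a ring with a hetero atom and a hydrogen-bond acceptor, without a step beyond the scatter from any of the three earlier compounds. No separate measurement is available that could explain why the ring exchange leaves the number within the scatter.

Because compound 4 changes the ring atoms and the attached group together, the compounds shown cannot separate the contribution of the ring nitrogen from that of the chlorine, a question that a 4-chlorophenyl group could help to answer. From the compounds shown here alone, all four compounds also carry a six-membered aromatic ring at this place, so it remains open whether a saturated ring such as piperidin-4-yl, or a ring bearing an amine or a carboxylic acid, would move the number beyond the scatter.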